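The compounds below may be only part of what the source reports. "The series", "measured", "known", "first", "only" and "open" are said of these compounds alone.

Of the compounds shown here, two sharing one core have been tested in an assay on CHO cells for displacement of a labelled ligand from adenosine receptor A1 (Homo sapiens), read by scintillation counting, with a stated time of 1 h, tested at 1 uM; on this read-out higher numbers stand for more inhibition at the one concentration tested (going by the name of the read-out) and lower numbers for less inhibition. Compound 1, with the structure `COc1cccc(-c2cnc(N)nc2-c2ccccc2)c1`, gives > 80% in this assay, and that figure is a limit of the measurement rather than a number. Going by the values given here, compound 2, with the structure `Clc1cccc(-c2cnc(Nc3ccccc3)nc2-c2ccccc2)c1`, gives 34% in this assay, which makes it the only compound with a number on record. The other value reported, that of compound 1, is the limit described in the limit of > 80% in this assay, at which 1 of the 2 values shown sits. Among the compounds with values here, no pair of measured compounds differs in a single place, so no measured step is available to lean on.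

The next compound, compound 3, has the structure `CN(C)CCNc1ncc(-c2cccc(Cl)c2)c(-c2ccccc2)n1`. It differs from compound 2 by 2-(dimethylamino)ethyl in place of phenyl on a nitrogen on an aromatic ring. There is no measured precedent for a change of this kind in this series, so the size and direction of its effect are open.

The step of a number 6 percentage points higher from compound 2 to compound 3 (within the scatter) is expected to be modest and within the usual scatter of this assay. Compound 3 is expected to give 40%, with a range running from 10% to 75%.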

Compound 3, a percentage reported as inhibition, at one concentration (the size of the read-out at that concentration, not a potency): 52%
For compound 3 the middle estimate is 12 percentage points below the measured one; low and high end bracket the measured number.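

Going by these compounds alone, replacing anilino with (2-(dimethylamino)ethyl)amino on the shared core gives a number 18 percentage points higher from compound 2 to compound 3 (beyond the scatter) in this assay and provides the first measured change at this position. In this one pair, the phenyl on the nitrogen is not needed for inhibition at the single concentration tested, since compound 3 carries a chain with no ring and still scores better than compound 2. Nothing on hand gives a reason for this step, so the pair records what happened without explaining it.

The step swaps two things at once, removing an aromatic ring and bringing in a chain that ends in a dimethylamino group, so it cannot say which of these matters. A plain ethyl group on the same nitrogen would have no terminal amine and would help separate the two, while a longer chain ending in the same dimethylamino group would show whether the distance from the core matters, and any such reading would still give the size of the inhibition at one concentration rather than a potency.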